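Swapping Methyl for Fluoro on Compound 3

The compounds below may be only part of what the source reports. "The series", "measured", "known", "first", "only" and "open" are said of these compounds alone.

In an ADME assay on MT4 cells (Homo sapiens) for cytotoxicity, read by MTT assay (on this read-out higher numbers stand for lower toxicity in this test and lower numbers for higher toxicity in this test), compound 1 (`COC(=O)c1ccc(NC(=O)CSc2nncnc2-c2cccc3ccccc23)c(Br)c1`) gives 173000 nM while compound 2 (`O=C(CSc1nncnc1-c1ccccc1Cl)Nc1cccnc1Cl`) gives 167000 nM and compound 3 (`Cc1ccccc1NC(=O)CSc1nncnc1-c1cccc2ccccc12`) gives 158000 nM in the same test. These three numbers all lie within the usual scatter of one another, so compound 3 stands level with the other two even though their structures differ in more than one place.

Compound 4 (`O=C(CSc1nncnc1-c1cccc2ccccc12)Nc1ccccc1F`) is compound 3 with one small edit, fluoro in place of methyl on an aromatic carbon, ortho to a large group (fluoro in place of methyl on an aromatic carbon). Going by the values given here, no measured pair shows this exact change, so the expectation rests only on the closeness of the three values, with compound 3 at 158000 nM as the starting point. The expected step of a 1.0-fold higher number from compound 3 to compound 4 (0.01 log units; within the scatter) stays within the scatter, with neither direction favoured. For compound 4 the estimated value is 160000 nM with an expected range from 70000 nM to 280000 nM in this measurement.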

Compound 4, half-maximal cytotoxic concentration: 65000 nM
Compound 4: middle estimate off by 2.5-fold (0.39 log units), on the high side, and the stated range ends above it.
By their numbers in this assay, from the lowest: compound 4; then compounds 3, 2 and 1 (each within the scatter of the next).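

In this assay the step is a 2.4-fold lower number from compound 3 to compound 4 (0.39 log units; beyond the scatter), so the swap of methyl for fluoro moves compound 4 towards higher toxicity in this test. Going by these compounds alone, no two of the earlier compounds differ in only one place, so they could not show what this pair does: a change of a single heavy atom on an aromatic carbon, ortho to a large group, can shift the number by more than the usual scatter. The step is modest, but it shows that this position is not indifferent to what sits on it.

Still open, as far as these compounds go, is whether an amine or a methoxy group at the same place would move the number further, and whether the same swap would do the same with the other parts of the molecule changed. Nothing shown here gives a reason for the step.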